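From a dimethylamino aryl group to a hydroxy-methoxy one

The source may report more compounds than this note shows. Statements on the series, on what has been measured and on what is new or still open speak of the compounds shown alone.

Compound 1 `CC(C)=C1C(=O)N(c2ccc(Cl)cc2)N(c2ccc(Cl)cc2)C1=O`: 39000 nM
Compound 2 `CN(C)c1ccc(C=C2C(=O)N(c3ccc(Cl)cc3)N(c3ccc(Cl)cc3)C2=O)cc1`: 80200 nM
Compound 3 `COc1cc(C=C2C(=O)N(c3ccc(Cl)cc3)N(c3ccc(Cl)cc3)C2=O)cc(OC)c1OC`: 17300 nM

In a functional assay on MGC-803 cells (Homo sapiens) for cytotoxicity, read by MTT assay, with a stated time of 72 h (a lower number here means a stronger inhibitor, a higher number a weaker inhibitor), compound 2 gives 80200 nM, the highest of the three numbers and beyond the scatter from both others. Compound 4 `COc1cc(C=C2C(=O)N(c3ccc(Cl)cc3)N(c3ccc(Cl)cc3)C2=O)ccc1O` departs from it in one place: 4-hydroxy-3-methoxyphenyl in place of 4-(dimethylamino)phenyl on a double-bonded chain carbon bound to a double-bonded ring carbon. There, 4-hydroxy-3-methoxyphenyl stands in place of 4-(dimethylamino)phenyl. Within the data shown here, no measured pair isolates this change. The nearest guide is compound 3, which also carries an oxygen-substituted phenyl group and gives 17300 nM. A moderate step toward a lower number, beyond the scatter, is therefore expected, and the estimated step is a 3.2-fold lower number from compound 2 to compound 4 (0.51 log units; beyond the scatter). The expected value for compound 4 is 25000 nM, within an estimated range of 9000 nM to 70000 nM.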

Compound 4, half-maximal inhibitory concentration: 21800 nM
Compound 4: the middle estimate sits 1.1-fold (0.06 log units) above what was measured; measured number inside the range.
By their numbers in this assay, from the lowest: compounds 3, 4 and 1 (each within the scatter of the next, the first and the last beyond it); then compound 2.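

In this assay, among these compounds, 4-hydroxy-3-methoxyphenyl in place of 4-(dimethylamino)phenyl gives a 3.7-fold lower number from compound 2 to compound 4 (0.57 log units; beyond the scatter), the first step here that isolates a single change at this position. It shows that the number responds to the aryl group on the double-bonded chain carbon, though the step is modest. No measurement shown here gives a cause for it. The compounds shown leave open whether the hydroxy or the methoxy group carries the step, since neither is varied alone. Also open, from the compounds shown here alone, is how a phenyl group bearing a carboxylic acid would read at this position.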